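Swapping a nitrile-bearing ring for a halogenated one

The source may hold more compounds than are shown below. What is called first, only, known or untested is meant among the compounds shown, and "the series" means these compounds.

Measured so far:
Compound 1, `O=C(NC1CCCCC1)c1ccccc1OCc1ccccc1`: 43400 nM
Compound 2, `O=C(Nc1cccnc1)c1ccccc1OCc1ccccc1C(F)(F)F`: 2100 nM
Compound 3, `N#Cc1cccc(COc2ccccc2C(=O)Nc2cccnc2)c1`: 60700 nM

In an assay on lysate for inhibition of phosphatidylcholine:ceramide cholinephosphotransferase 2 (Homo sapiens), read by HPLC, with stated times of 30 min and 2 h (on this read-out higher numbers stand for weaker inhibition and lower numbers for stronger inhibition), compound 3 gives the highest of the three numbers; it sits within the scatter of compound 1 and well apart from compound 2. Compound 4, `O=C(Nc1cccnc1)c1ccccc1OCc1cccc(Cl)c1F`, is not yet measured. It differs from compound 3 in one place: 3-chloro-2-fluorophenyl in place of 3-cyanophenyl on a saturated chain carbon bound to an oxygen on an aromatic ring. Among the measured compounds shown here, no measured pair shows this exact exchange, so the size of the step is open. Since compound 2, which carries a trifluoromethyl-bearing ring, gives 2100 nM in this assay, a move toward stronger inhibition is expected for compound 4, with the step from compound 3 estimated at a 7.6-fold lower number from compound 3 to compound 4 (0.88 log units; beyond the scatter). Compound 4 is expected to give about 8000 nM, in a range of 2000 nM to 30000 nM.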

Compound 4, half-maximal inhibitory concentration: 3100 nM
Estimate against measurement, compound 4: 2.6-fold (0.41 log units) above, and the stated range covers the measured number.
By their numbers in this assay, from the lowest: compounds 2 and 4 (each within the scatter of the next); then compounds 1 and 3 (each within the scatter of the next).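

In this assay the first step read at this position is large: a 20-fold lower number from compound 3 to compound 4 (1.29 log units; beyond the scatter). The ring on this saturated chain carbon therefore matters strongly, and compound 4 lands within the scatter of compound 2, which carries a trifluoromethyl-bearing ring there. Nothing at hand explains why this exchange has so large an effect. Chlorine and fluorine enter together, so their separate shares in the step remain open. From the compounds shown here alone, how a ring bearing an amine or a carboxylic acid would behave at this position also remains open.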